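Replacing chloro with hydroxy in compound 2

The source may report more compounds than this note shows. Statements on the series, on what has been measured and on what is new or still open speak of the compounds shown alone.

Among the compounds with values here, in a functional assay on A-431 cells (Homo sapiens) for cytotoxicity, read by MTT assay, with a stated time of 72 h (a higher number here means a weaker inhibitor of growth, a lower number a stronger inhibitor of growth), compound 2 `N#C/C(=C/c1ccc(Cl)cc1)C(=O)c1ccc[nH]1` gives 31000 nM, the only actual number so far. Compound 1 `N#C/C(=C/c1ccc2ccccc2c1)C(=O)c1ccc[nH]1` gives < 10000 nM, which is a limit. Compound 3 `N#C/C(=C/c1ccc(Cl)c(Cl)c1)C(=O)c1ccc[nH]1` gives < 10000 nM, also a limit. Together these two make up (the limit of < 10000 nM in this assay, at which 2 of the 3 values shown sit).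

Compound 4 `N#C/C(=C/c1ccc(O)cc1)C(=O)c1ccc[nH]1` carries hydroxy in place of chloro on an aromatic carbon, para to a large group: hydroxy in place of chloro on an aromatic carbon. Within the data shown here, the only measured step, an at least 3.1-fold lower number from compound 2 to compound 3 (0.49 log units; beyond the scatter), adds a chloro and removes none, so it bears only loosely on this exchange. No step beyond the scatter is therefore expected in this assay. The expected change is a 1.6-fold lower number from compound 2 to compound 4 (0.19 log units; within the scatter). Compound 4 is estimated at 20000 nM, with an expected range from 6000 nM to 60000 nM.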

Compound 4, concentration for 50% growth inhibition: < 10000 nM
Compound 4 ended at the assay's limit; the forecaster's own chance of this, stated with the estimate: 30%; middle value at least 2.0-fold (0.30 log units) away from the limit.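

In this assay, hydroxy in place of chloro on an aromatic carbon gives an at least 3.1-fold lower number from compound 2 to compound 4 (0.49 log units; beyond the scatter) and so shows that the chloro of compound 2 is not needed here for the lower number. Compound 3 had shown only that a second chloro lowers it, whereas this exchange removes the chloro altogether. Compound 4 gives < 10000 nM as a limit.

From the compounds shown here alone, the true size of this step, and any order among compound 1, compound 3 and compound 4, stays open: the limit of < 10000 nM in this assay, at which 3 of the 4 values shown sit. Also open, going by these compounds, is how an amine or a carboxylic acid would fare in this place.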